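Swapping a Side Group: Does Cell Tolerance Change?

This account rests on a few compounds, and the source may have more. Where it says the series, first, only, none or still open, it means among the compounds named here.

Compound 1, `OC[C@H]1O[C@@H](n2cnc3c(COc4ccccn4)ncnc32)[C@H](O)[C@@H]1O`: > 250000 nM, a limit of the assay rather than a number.
Compound 2, `OC[C@H]1O[C@@H](n2cnc3c(COc4ccccc4)ncnc32)[C@H](O)[C@@H]1O`: > 100000 nM, likewise a limit of the assay.
Compound 3, `O=c1ccccn1Cc1ncnc2c1ncn2[C@@H]1O[C@H](CO)[C@@H](O)[C@H]1O`: > 100000 nM, again a limit of the assay.

All three compounds were tested in a functional assay on Huh-7 cells (Homo sapiens) for cytotoxicity, read by MTT assay, with a stated time of 3 days (a lower number here means that less compound is tolerated, a higher number that more compound is tolerated), and none of them gave a number: for each of them the assay reported only a limit. Compound 1 stands at the higher of the two limits seen here, (the limit of > 250000 nM in this assay, at which 1 of the 3 values shown sits), while compound 2 and compound 3 sit at the limit of > 100000 nM in this assay, at which 2 of the 3 values shown sit.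

The unmeasured compound 4, `CC(C)N(Cc1ncnc2c1ncn2[C@@H]1O[C@H](CO)[C@@H](O)[C@H]1O)C(C)C`, differs from compound 1 in one place: diisopropylamino in place of (pyridin-2-yl)oxy on a saturated chain carbon bound to an aromatic carbon. Two measured steps start from compound 1 and change the same side group. The step that the two limits leave unreadable from compound 1 to compound 2 and the step that the two limits leave unreadable from compound 1 to compound 3 are both unreadable in size, since every value involved is a limit. The same holds for a step that the two limits leave unreadable from compound 2 to compound 3. So the shared core tolerated three different side groups at this position without any sign of cytotoxicity up to the limits tested, and nothing in these data points to a direction for compound 4.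

The expectation for compound 4 is therefore again a value at or beyond the range tested, a step of an at least 1.2-fold lower number from compound 1 to compound 4 (0.09 log units; that floor lies within the scatter) that is more likely to be reported as a limit than as a number. Compound 4 is estimated at 200000 nM, between 50000 nM and 500000 nM.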

Compound 4, half-maximal cytotoxic concentration: 18000 nM
Beside the measured number, compound 4's estimate is 11-fold (1.05 log units) above it; measured number outside the range, below it.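

In this assay, among these compounds, this position turns out not to be indifferent, as the earlier compounds might have suggested: diisopropylamino on the saturated chain carbon bound to an aromatic carbon gives an at least 13-fold lower number from compound 1 to compound 4 (1.14 log units; beyond the scatter), and the same group gives an at least 5.5-fold lower number from compound 2 to compound 4 (0.74 log units; beyond the scatter) and an at least 5.5-fold lower number from compound 3 to compound 4 (0.74 log units; beyond the scatter). Among these four compounds, the side groups of compound 1, compound 2 and compound 3 each carry a six-membered aromatic ring and stay at a limit of the assay, whereas the group in compound 4 has no ring and is the only one to give a number, and no compound shown goes against this split. The steps among compound 1, compound 2 and compound 3 cannot be read, and the three new steps are floors rather than exact sizes because their starting values are limits, as with this one: the limit of > 100000 nM in this assay, at which 2 of the 4 values shown sit.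

The compounds shown leave open whether the lower number goes with the loss of the ring, with the amine nitrogen or with the two isopropyl branches. A dimethylamino group or a piperidin-1-yl group at the same place would help to tell these apart, since the first keeps the amine without the branches and the second puts the amine nitrogen inside a ring.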